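Removing the methoxy group from compound 1

The source may hold more compounds than are shown below. What is called first, only, known or untested is meant among the compounds shown, and "the series" means these compounds.

Within the data shown here, compound 1 `COc1cccc(/C=C/C(=O)c2sc(Nc3ccc(Cl)c(Cl)c3)nc2C)c1` is the only one of three measured compounds that yields a number in a functional assay on NCI-H460 cells (Homo sapiens) for cytotoxicity, read by MTT assay (on this read-out higher numbers stand for weaker inhibition and lower numbers for stronger inhibition), where compound 1 gives 20100 nM. Compound 2 `COc1cccc(/C=C/C(=O)c2sc(Nc3ccc(Cl)cc3)nc2C)c1` returns only a limit of the assay, > 25000 nM. Compound 3 `COc1cccc(/C=C/C(=O)c2sc(Nc3cccc(C)c3)nc2C)c1` likewise returns a limit, > 25000 nM, so two of the three values sit at the limit of > 25000 nM in this assay, at which 2 of the 3 values shown sit. The step of an at least 1.2-fold higher number from compound 1 to compound 2 (0.09 log units; that floor lies within the scatter) and the step of an at least 1.2-fold higher number from compound 1 to compound 3 (0.09 log units; that floor lies within the scatter) alter the group on the nitrogen and leave the 3-methoxyphenyl group untouched. Among the measured compounds shown here, compound 4 `Cc1nc(Nc2ccc(Cl)c(Cl)c2)sc1C(=O)/C=C/c1ccccc1` differs from compound 1 by hydrogen in place of methoxy on an aromatic carbon, a change that no measured step addresses. Since compound 1 gives 20100 nM, compound 4 is expected to show a 1.2-fold higher number from compound 1 to compound 4 (0.08 log units; within the scatter), most likely nothing beyond the scatter. The estimate for compound 4 is 24000 nM, between 10000 nM and 60000 nM.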

Compound 4, half-maximal inhibitory concentration: 22700 nM
The estimate for compound 4 lay 1.1-fold (0.02 log units) above the measured number; the range from low to high includes it.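

Replacing methoxy with hydrogen gives a 1.1-fold higher number from compound 1 to compound 4 (0.05 log units; within the scatter) in this assay. The earlier steps shown here changed only the group on the nitrogen, whereas this one touches the 3-methoxyphenyl group and shows that phenyl in its place still gives a number. At this position, the methoxy group is therefore not required for a readable value.

On these data alone, whether an amine or a carboxylic acid at this place would move the number stays open. A loss of activity there would be hard to size because values in this series already reach the limit: the limit of > 25000 nM in this assay, at which 2 of the 4 values shown sit.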